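A few compounds are considered here, and "the series" means these few. Any claim that something is new, unique, unknown or untested is made for them only; others in the source may bear on it.

In a functional assay on IGROV-1 cells (Homo sapiens) for inhibition, with a stated time of 72 h (a higher number here means a weaker inhibitor, a lower number a stronger inhibitor), compound 1 `O=C(/C=C/c1ccc(-c2ccccc2)cc1)NO` gives 3500 nM and compound 2 `NNC(=O)/C=C/c1ccc(-c2ccccc2)cc1` gives 7600 nM as the higher of the two numbers, which makes compound 2 the weaker inhibitor of this pair. Compound 3 `CC(=O)SCC(=O)/C=C/c1ccc(-c2ccccc2)cc1` now carries (acetylsulfanyl)methyl in place of aminoamino on a carbonyl carbon, a change counted as (acetylsulfanyl)methyl in place of aminoamino on a carbonyl carbon with the shared core untouched. For the measured compounds named here, only one measured step bears on this. Amino in place of hydroxy on an amide-type nitrogen gave a 2.2-fold higher number from compound 1 to compound 2 (0.34 log units; beyond the scatter) and counts as modest. Going by the values given here, no measured compound carries the new group, so any forecast of direction is weak. The expected change is small, with an estimated 1.5-fold lower number from compound 2 to compound 3 (0.18 log units; within the scatter) as the likely outcome. For compound 3 the estimated value is 5000 nM within an expected range from 1500 nM to 15000 nM in this assay once it is measured.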

Compound 3, half-maximal inhibitory concentration: 26400 nM
For compound 3 the middle estimate is 5.3-fold (0.72 log units) below the measured one; the measured number lies above the stated range.
By their numbers in this assay, from the lowest: compound 1; then compound 2; then compound 3.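

In this assay, putting (acetylsulfanyl)methyl in place of aminoamino on this carbonyl carbon gives a 3.5-fold higher number from compound 2 to compound 3 (0.54 log units; beyond the scatter) and so yields a weaker inhibitor, while the same group in place of hydroxyamino gives a 7.5-fold higher number from compound 1 to compound 3 (0.88 log units; beyond the scatter) as the wider gap. The earlier pair compared only two nitrogen-linked groups, whereas this result shows that a carbon-linked group with no hydrogen-bond donors is also tolerated less well here, leaving hydroxyamino the best of the three groups shown. Nothing available explains why the number rises with this change.

As far as these compounds go, it remains open whether the acetyl part, the sulfur or the loss of the nitrogen drives this rise. A free mercaptomethyl group or a carboxylic acid at this carbonyl position would help separate these possibilities.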